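Pyrrolidinone oxadiazoles: aryl swap on the ring nitrogen

A few compounds are considered here, and "the series" means these few. Any claim that something is new, unique, unknown or untested is made for them only; others in the source may bear on it.

Measured so far in an in vitro functional assay on HEK293-A cells for negative allosteric modulation of metabotropic glutamate receptor 5 (Homo sapiens), read by FLIPR and calcium flux; a higher number here means a weaker inhibitor, a lower number a stronger inhibitor:
- compound 1 `O=C1CC(c2nc(-c3cccc(Cl)c3)no2)CN1c1ccc(Cl)cc1`: > 10000 nM, a limit of the assay
- compound 2 `Cc1ccc(N2CC(c3nc(-c4cccc(Cl)c4)no3)CC2=O)cc1`: > 10000 nM, a limit of the assay
- compound 3 `Cc1ccc(N2CC(c3nc(-c4cccc(Cl)c4)no3)CC2=O)cc1C`: > 10000 nM, a limit of the assay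

Compound 3 stands where the whole series stands: at the limit (the limit of > 10000 nM in this assay, at which 3 of the 3 values shown sit), so no number is known for it and its place among the three cannot be ranked. The same holds for the steps among the measured compounds: a step that the two limits leave unreadable from compound 1 to compound 2, a step that the two limits leave unreadable from compound 1 to compound 3 and a step that the two limits leave unreadable from compound 2 to compound 3 are all unreadable, since each joins two limits.

Compound 4 `COc1cccc(N2CC(c3nc(-c4cccc(Cl)c4)no3)CC2=O)c1` differs from compound 3 by 3-methoxyphenyl in place of 3,4-dimethylphenyl on an amide-type nitrogen in a ring. Among the compounds with values here, none of the measured steps touches a methoxy group, so no step gives a direct size for this change; all that bears on it is that each aryl variation so far, chloro, methyl or dimethyl, has left the series at the limit. The expectation is therefore that compound 4 shows no readable change beyond the scatter, a step that the limit leaves unreadable from compound 3 to compound 4 in this assay, and is estimated at 15000 nM with a range from 4000 nM to 60000 nM, most likely reported again as a limit.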

Compound 4, half-maximal inhibitory concentration: 690 nM
Beside the measured number, compound 4's estimate is 22-fold (1.34 log units) above it; measured number below the stated range.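

In this assay, the aryl group on the amide-type nitrogen now shows a readable effect: placing 3-methoxyphenyl there gives an at least 14-fold lower number from compound 3 to compound 4 (1.16 log units; beyond the scatter), an at least 14-fold lower number from compound 2 to compound 4 (1.16 log units; beyond the scatter) and an at least 14-fold lower number from compound 1 to compound 4 (1.16 log units; beyond the scatter). The steps among compound 1, compound 2 and compound 3 cannot be read, and each of the three new sizes is a minimum, since each starts from a limit and not a number: the limit of > 10000 nM in this assay, at which 3 of the 4 values shown sit. Compound 4 is the only compound shown with a number, and its 3-methoxyphenyl brings an oxygen and a hydrogen-bond acceptor that 3,4-dimethylphenyl lacks.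

The compounds shown do not separate the effect of the methoxy group from that of where it sits, as none carries 3-methylphenyl or 4-methoxyphenyl. From the compounds shown here alone, how 3-ethoxyphenyl or 3-aminophenyl would compare also remains open.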